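Cytotoxicity on HEL cells: fluoro to methoxy on the pendant phenyl

The compounds below may be only part of what the source reports. "The series", "measured", "known", "first", "only" and "open" are said of these compounds alone.

Measured so far:
compound 1, `Cc1cc(-c2ccc(O)cc2)c2ncc(CSCCc3ccccc3)n2c1`: 20 ug/mL
compound 2, `Cc1cc(-c2ccccc2)c2ncc(CSCCc3ccccc3)n2c1`: 20 ug/mL
compound 3, `Cc1cc(-c2cccc(F)c2)c2ncc(CSCCc3ccccc3)n2c1`: 20 ug/mL

All three compounds share one core and differ only on the pendant phenyl ring. In an ADME assay on HEL cells (Homo sapiens) for cytotoxicity, with a stated time of 3 days (a lower number here means that less compound is tolerated, a higher number that more compound is tolerated), compound 3 gives 20 ug/mL, and it stands level with compound 1 and compound 2: no change at the digits printed from compound 1 to compound 3 (within the scatter), no change at the digits printed from compound 2 to compound 3 (within the scatter). The remaining pair also shows nothing: no change at the digits printed from compound 1 to compound 2 (within the scatter).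

Compound 4, `COc1cccc(-c2cc(C)cn3c(CSCCc4ccccc4)cnc23)c1`, is not yet measured. It differs from compound 3 by methoxy in place of fluoro on an aromatic carbon. Within the data shown here, the closest precedent is the step that put fluoro in place of hydrogen at this ring, no change at the digits printed from compound 2 to compound 3 (within the scatter), and the step that exchanged 4-hydroxyphenyl for 3-fluorophenyl, no change at the digits printed from compound 1 to compound 3 (within the scatter); neither substituent change on the pendant ring moved the value. Among the measured compounds shown here, nothing among the measured compounds suggests that methoxy in place of fluoro should behave differently, so no step beyond the scatter is expected in this assay.

For compound 4 the expected value in this assay is 20 ug/mL, with a range of 10 ug/mL to 40 ug/mL. The estimated step is no change at the digits printed from compound 3 to compound 4 (within the scatter), which is expected to lie within the scatter.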

Compound 4, minimum cytotoxic concentration: 100 ug/mL
Compound 4: middle estimate off by 5.0-fold (0.70 log units), on the low side, outside the stated range (above it).
By their numbers in this assay, from the lowest: compounds 1, 2 and 3 (each within the scatter of the next); then compound 4.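

In this assay the pendant phenyl ring is no longer silent: methoxy in place of fluoro, on the aromatic carbon meta to a large group, gives a 5.0-fold higher number from compound 3 to compound 4 (0.70 log units; beyond the scatter). Methoxy in place of hydrogen gives a 5.0-fold higher number from compound 2 to compound 4 (0.70 log units; beyond the scatter), and 3-methoxyphenyl in place of 4-hydroxyphenyl gives a 5.0-fold higher number from compound 1 to compound 4 (0.70 log units; beyond the scatter), so among these compounds only the methoxy compound stands apart, while the hydroxy, hydrogen and fluoro compounds stay level. Nothing measured here accounts for this step.

As far as these compounds go, it remains open whether the higher number is specific to methoxy or extends to other groups at this carbon, such as ethoxy, an amine or a carboxylic acid. From the compounds shown here alone, it is also open whether 4-methoxyphenyl would match 3-methoxyphenyl.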